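A few compounds are considered here, and "the series" means these few. Any claim that something is new, unique, unknown or untested is made for them only; others in the source may bear on it.

Of the compounds shown here, three built on the same core have been measured in a functional assay on isolated protein for inhibition of Glucose-dependent insulinotropic receptor (Rattus norvegicus), read by HTRF and cAMP accumulation; on this read-out lower numbers stand for an effect already at smaller amounts and higher numbers for an effect only at larger amounts of compound. Compound 1 `Cc1nc(S(C)(=O)=O)ccc1Oc1ncnc(OC2CCN(C(=O)OC3CCC3)CC2)c1F` gives 167 nM in this assay. Compound 2 `Cc1nc(S(C)(=O)=O)ccc1Oc1ncnc(OC2CCN(C(=O)OC3(C(F)(F)F)COC3)CC2)c1F` gives 342 nM, and compound 3 `Cc1nc(S(C)(=O)=O)ccc1Oc1ncnc(OC2CCN(C(=O)SC3(C)CC3)CC2)c1F` gives 166 nM. Of the three numbers, compound 3 has the lowest, but its gap to compound 1 is within the scatter, so the two cannot be ordered; only compound 2 stands apart, as the step of a 2.1-fold lower number from compound 2 to compound 3 (0.31 log units; beyond the scatter) shows. The step of a 2.0-fold higher number from compound 1 to compound 2 (0.31 log units; beyond the scatter) describes the other change at the group on the oxygen. The step of a 1.0-fold lower number from compound 1 to compound 3 (0.00 log units; within the scatter) is the one that bears most on what follows, since it exchanges the whole group on the carbonyl carbon without moving the number.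

Compound 4 `Cc1nc(S(C)(=O)=O)ccc1Oc1ncnc(OC2CCN(C(=O)SC3CCC3)CC2)c1F` is the next compound. It differs from compound 3 by cyclobutyl in place of 1-methylcyclopropyl on a sulfur. Within the data shown here, no measured step exchanges one ring for another on the sulfur, so the expectation rests on the step of a 1.0-fold lower number from compound 1 to compound 3 (0.00 log units; within the scatter), which left the number unchanged when the group on the carbonyl carbon was swapped. Compound 4 is therefore expected to give a step of a 1.1-fold higher number from compound 3 to compound 4 (0.02 log units; within the scatter), nothing beyond the scatter. Compound 4 is estimated at 175 nM in this assay, with a range from 80 nM to 380 nM.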

Compound 4, half-maximal effective concentration: 77.4 nM
Beside the measured number, compound 4's estimate is 2.3-fold (0.35 log units) above it, outside the stated range (below it).
By their numbers in this assay, from the lowest: compound 4; then compounds 3 and 1 (each within the scatter of the next); then compound 2.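

In this assay, the group on the sulfur turns out to matter, even though the two groups exchanged have the same atoms, joined differently: the change to cyclobutyl gives a 2.1-fold lower number from compound 3 to compound 4 (0.33 log units; beyond the scatter). With cyclobutyl held constant, cyclobutylsulfanyl in place of cyclobutyloxy gives a 2.2-fold lower number from compound 1 to compound 4 (0.33 log units; beyond the scatter), so the unchanged number seen earlier when the whole group on the carbonyl carbon was exchanged does not hold for this pair, and cyclobutylsulfanyl in place of (3-(trifluoromethyl)oxetan-3-yl)oxy gives the widest step, a 4.4-fold lower number from compound 2 to compound 4 (0.65 log units; beyond the scatter). Nothing available explains these differences.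

On these data alone, whether the trend continues with a larger ring on the sulfur, such as cyclopentyl, or with an open chain, such as isopropyl, remains open. Also open, as far as these compounds go, is how 1-methylcyclopropyl would behave on an oxygen.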